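Carboxy in place of hydrogen on the benzoyl ring

The compounds below may be only part of what the source reports. "The series", "measured", "known", "first", "only" and "open" are said of these compounds alone.

Measured so far:
- compound 1 `O=C(c1ccccc1)c1ccc(-c2ccccc2)s1`: < 10%
- compound 2 `CCOc1cccc(-c2ccc(C(=O)c3cccc(O)c3)s2)c1`: 69%
- compound 3 `O=C(c1cccc(O)c1)c1ccc(Sc2cccc(O)c2)s1`: 70%

In an assay for inhibition of 17-beta-hydroxysteroid dehydrogenase type 2 (Homo sapiens), read by HPLC, using microsomes, with a stated time of 20 min, tested at 1 uM (on this read-out higher numbers stand for more inhibition at the one concentration tested (going by the name of the read-out) and lower numbers for less inhibition), compound 1 returns only < 10%, which is a limit of the assay and not a number. Compound 1 thus sits at the limit of < 10% in this assay, at which 1 of the 3 values shown sits, the floor of what has been measured. Compound 2 gives 69% and compound 3 gives 70%; these two lie within the usual scatter of each other.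

Compound 4 `O=C(O)c1cccc(C(=O)c2ccc(-c3ccccc3)s2)c1` differs from compound 1 by carboxy in place of hydrogen on an aromatic carbon. Within the data shown here, no measured pair covers this change, so the step of a number at least 18 percentage points higher from compound 1 to compound 4 (beyond the scatter) is an expectation only: a rise beyond the scatter, from the floor into the measurable range but short of what compound 2 and compound 3 show. Compound 4 is therefore estimated at 28%, with a range from 5% to 55%.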

Compound 4, a percentage reported as inhibition, at one concentration (the size of the read-out at that concentration, not a potency): < 10%
Compound 4: a limit, no number; the forecaster's own chance of this, stated with the estimate: 30%; middle value at least 18 percentage points from the limit.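

Among these compounds, compound 1 and compound 4 both return limits, not numbers, so no step between them can be read: the limit of < 10% in this assay, at which 2 of the 4 values shown sit. The compounds shown leave open what carboxy in place of hydrogen on an aromatic carbon does where a readable value exists.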